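Swapping an Aromatic Acyl Group for a Short Amine Chain

This account rests on a few compounds, and the source may have more. Where it says the series, first, only, none or still open, it means among the compounds named here.

Compound 1 `NC[C@@H]1CCCc2cc(S(=O)(=O)c3cn[nH]c3)ccc21` and compound 2 `O=C(NC[C@@H]1CCCc2cc(S(=O)(=O)c3cccc(F)c3)ccc21)c1ccc[nH]1` share a common core and were both tested in an assay on isolated protein for displacement of a labelled ligand from 5-hydroxytryptamine receptor 6 (Homo sapiens); on this read-out higher numbers stand for weaker inhibition and lower numbers for stronger inhibition. In this assay compound 1 gives 2 nM. In this assay compound 2 gives 5.01 nM, the higher of the two numbers, so compound 2 is the weaker binder of the pair, and the gap between them lies beyond the usual scatter. Compound 3 `CNCC(=O)NC[C@@H]1CCCc2cc(S(=O)(=O)c3cccc(F)c3)ccc21` has not yet been measured. It differs from compound 2 in one place: (methylamino)methyl in place of 1H-pyrrol-2-yl on a carbonyl carbon. The group on the carbonyl carbon thus changes from a five-membered aromatic ring to a short chain with no ring. Within the data shown here, no measured step of this kind is available, so no change beyond the scatter is expected in this assay, and the step from compound 2 to compound 3 is estimated as a 1.0-fold lower number from compound 2 to compound 3 (0.00 log units; within the scatter). Compound 3 is expected to give about 5 nM in this assay, with a likely range from 1.2 nM to 20 nM.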

Compound 3, inhibition constant: 0.159 nM
Estimate against measurement, compound 3: 31-fold (1.50 log units) above, and the stated range ends above it.
By their numbers in this assay, from the lowest: compound 3; then compound 1; then compound 2.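

On the carbonyl carbon, replacing 1H-pyrrol-2-yl with (methylamino)methyl in this assay gives a 32-fold lower number from compound 2 to compound 3 (1.50 log units; beyond the scatter) and marks this as a position where the choice of group matters greatly. The earlier compounds shown here could not show this, as they differ in more than one place, whereas this pair shows that a five-membered aromatic ring is not needed here for strong binding: a short chain with no ring does better. No measurement shown here accounts for the size of this step.

The swap removes the ring and brings in the methylamino group at once, and the compounds shown do not separate those two changes. A plain methyl group on the same carbonyl carbon, or a longer chain ending in a dimethylamino group, would help tell them apart.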